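Sulfanyl purine acyclic series: amino to fluoro step

This account rests on a few compounds, and the source may have more. Where it says the series, first, only, none or still open, it means among the compounds named here.

Measured compounds:
Compound 1 `CC(=O)OCCOn1cnc2c(Cl)nc(N)nc21` sits at the limit of a functional assay on HeLa cells (Homo sapiens) for inhibition (a lower number here means a stronger inhibitor, a higher number a weaker inhibitor), with > 500000 nM.
Compound 2 `COc1nc(I)nc2c1ncn2OCCO` also sits at a limit in this assay with > 500000 nM.
Compound 3 `CC(=O)OCCOn1cnc2c(S)nc(N)nc21` gives a number in this assay, 5000 nM.

Among the measured compounds shown here, compound 3 is the only compound of the three with a measured number; the other two values are limits. For the measured compounds named here, the one measured step is an at least 100-fold lower number from compound 1 to compound 3 (2.00 log units; beyond the scatter), and its size is tied to the limit of > 500000 nM in this assay, at which 2 of the 3 values shown sit, so its true extent is not known.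

Compound 4 `CC(=O)OCCOn1cnc2c(S)nc(F)nc21` differs from compound 3 by fluoro in place of amino on an aromatic carbon. Going by the values given here, the measured step from compound 1 to compound 3 concerns the sulfanyl group on a different carbon; no measured step touches the carbon between two ring nitrogen atoms where the amino group leaves and the fluoro enters. Among the compounds with values here, the expectation therefore rests only on compound 3 and its position as the single numbered value.

Compound 4 is expected to give a higher number in this assay than compound 3, with the step of a 4.0-fold higher number from compound 3 to compound 4 (0.60 log units; beyond the scatter) estimated as moderate and with wide uncertainty. Compound 4 is estimated at 20000 nM, within a range from 3000 nM to 150000 nM, and a limit-only result is a real possibility.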

Compound 4, half-maximal inhibitory concentration: > 500000 nM
Compound 4 ended at the assay's limit; the forecaster's own chance of this, stated with the estimate: 30%; at least 25-fold (1.39 log units) between middle value and limit.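

In this assay, among the compounds shown here, fluoro in place of amino gives an at least 100-fold higher number from compound 3 to compound 4 (2.00 log units; beyond the scatter), the first measured step at the carbon between two ring nitrogen atoms, and it shows that this position is not indifferent to the change. The earlier step placed the sulfanyl group only in a compound that also carries amino, whereas compound 4 keeps the sulfanyl group and still gives > 500000 nM, which is a limit. A sulfanyl group on the shared core is therefore not enough to give a number in this assay, and the true extent of the new step stays unknown, as its size is tied to the assay limit: the limit of > 500000 nM in this assay, at which 3 of the 4 values shown sit.

With the sulfanyl group in place, only amino and fluoro are shown on this carbon, so the step cannot separate the loss of amino from the entry of fluoro, nor say which feature of amino matters. A methylamino or dimethylamino group at this carbon would test whether any nitrogen substituent retains a number, and whether the hydrogen-bond donor count of amino is what counts.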